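The compounds below may be only part of what the source reports. "The series", "measured", "known", "first", "only" and "open" are said of these compounds alone.

The measured compounds, each tested in a functional assay, read by spectrophotometry, with a stated time of 2 h, tested at 0.5 mg/mL; a higher number here means a stronger effect of the compound at the concentration tested, a lower number a weaker effect:

Compound 1, `CC(C)[C@@H]1CC[C@@H](C)C[C@@]12N(C)C(=O)[C@@H]1[C@H]3C(=O)N(C)C(=O)[C@H]3ON12`, gives 36.5%.
Compound 2, `CC(C)[C@@H]1CC[C@@H](C)C[C@@]12N(C)C(=O)[C@@H]1[C@H]3C(=O)N(c4ccc(Cl)cc4)C(=O)[C@H]3ON12`, gives 47.5%.
Compound 3, `COc1ccc(N2C(=O)[C@H]3[C@H](ON4[C@@H]3C(=O)N(C)[C@@]43C[C@H](C)CC[C@H]3C(C)C)C2=O)cc1`, gives 44.5%.

All three share the same core and differ only in the group on one amide-type nitrogen in a ring. Compound 3 stands second of the three numbers, but its distance to compound 2, a number 3 percentage points lower from compound 2 to compound 3 (within the scatter), lies within the scatter, as does its distance to compound 1, a number 8 percentage points higher from compound 1 to compound 3 (within the scatter), so no ranking among them can be claimed with confidence.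

Compound 4, `CC(C)[C@@H]1CC[C@@H](C)C[C@@]12N(C)C(=O)[C@@H]1[C@H]3C(=O)N(c4ccc5ccccc5c4)C(=O)[C@H]3ON12`, has not yet been measured. It differs from compound 3 in one place: naphthalen-2-yl in place of 4-methoxyphenyl on an amide-type nitrogen in a ring.

For the measured compounds named here, two measured steps bear on this change, both replacing the methyl on that nitrogen with an aromatic group: a number 11 percentage points higher from compound 1 to compound 2 (beyond the scatter), and a number 8 percentage points higher from compound 1 to compound 3 (within the scatter). Swapping one aromatic group for another, a number 3 percentage points lower from compound 2 to compound 3 (within the scatter), changed little. Since compound 4 again carries an aromatic group at the same place, the expected step of a number 2.5 percentage points higher from compound 3 to compound 4 (within the scatter) is none beyond the scatter. Compound 4 is therefore estimated to give 47% in this assay, within a range of 35% to 60%.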

Compound 4, a percentage reported as activity, at one concentration (the size of the read-out at that concentration, not a potency): 24.5%
Compound 4: the middle estimate sits 22.5 percentage points above what was measured, and the stated range ends above it.
By their numbers in this assay, from the lowest: compound 4; then compounds 1, 3 and 2 (each within the scatter of the next, the first and the last beyond it).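

For the compounds shown here, the position on this nitrogen is more sensitive than the earlier compounds suggested: swapping 4-chlorophenyl for 4-methoxyphenyl changed little, but naphthalen-2-yl brings a clear fall in this assay (a number 20 percentage points lower from compound 3 to compound 4 (beyond the scatter)) and an equally clear one against the chloro analogue (a number 23 percentage points lower from compound 2 to compound 4 (beyond the scatter)). An aromatic group here is therefore not enough in itself to keep the number up, since this one, with two six-membered aromatic rings rather than one, also ends up under the plain methyl (a number 12 percentage points lower from compound 1 to compound 4 (beyond the scatter)), making compound 4 the lowest of the four. Nothing available explains this fall, whether through a measured property of the group or otherwise.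

The change adds a second ring and also removes the chloro or methoxy group, and these compounds cannot separate the two. As far as these compounds go, whether an unsubstituted phenyl, a benzyl group or a longer chain such as butyl on this nitrogen would sit with compound 2 and compound 3 or with compound 4 remains open.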